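A few compounds are considered here, and "the series" means these few. Any claim that something is new, unique, unknown or untested is made for them only; others in the source may bear on it.

Compound 1 `CCOC(=O)c1cc2ccc(OCCCn3cc(CNC(=O)CCCCC4CCSS4)nn3)cc2oc1=O`: 49.2%
Compound 2 `COc1ccc(-c2cc3ccc(OCCCn4cc(CNC(=O)CCCCC5CCSS5)nn4)cc3oc2=O)cc1`: 65.7%

In a functional assay on PC-12 cells (Rattus norvegicus) for cytotoxicity, read by MTT assay, with stated times of 3 h and 2 h, tested at 50 uM (a lower number here means a weaker effect, a higher number a stronger effect of the compound at the concentration tested), compound 2 stands highest of the two numbers; its nearest neighbour is compound 1, and the change a number 16.5 percentage points higher from compound 1 to compound 2 (beyond the scatter) lies beyond the scatter. Compound 3 `O=C(CCCCC1CCSS1)NCc1cn(CCCOc2ccc3cc(-c4ccc(Cl)c(Cl)c4)c(=O)oc3c2)nn1` differs from compound 2 by 3,4-dichlorophenyl in place of 4-methoxyphenyl on an aromatic carbon. For the measured compounds named here, no measured step exchanges one aryl group for another; the only step known concerns a different group, so it gives no direct guide. An estimated step of a number 2.7 percentage points lower from compound 2 to compound 3 (within the scatter), within the scatter, is therefore expected. Compound 3 is estimated to give 63%, in the range 46% to 80%.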

Compound 3, a percentage reported as activity, at one concentration (the size of the read-out at that concentration, not a potency): 54.8%
Beside the measured number, compound 3's estimate is 8.2 percentage points above it; low and high end bracket the measured number.
By their numbers in this assay, from the lowest: compounds 1 and 3 (each within the scatter of the next); then compound 2.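

Swapping 4-methoxyphenyl for 3,4-dichlorophenyl at this position gives a number 10.9 percentage points lower from compound 2 to compound 3 (beyond the scatter) in this assay, so the read-out here depends on more than the presence of an aryl ring on this aromatic carbon. Ethoxycarbonyl and 3,4-dichlorophenyl, by contrast, are not told apart, with a number 5.6 percentage points higher from compound 1 to compound 3 (within the scatter). No available evidence bears on why the numbers fall this way.

From the compounds shown here alone, what an unsubstituted phenyl, a 4-chlorophenyl or a carboxylic acid would give at this position remains open. So does whether the step from 4-methoxyphenyl to 3,4-dichlorophenyl would hold on a different linker.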